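Lipophilicity notes: replacing the anilino side chain by a cyclic carbamate

The source may report more compounds than this note shows. Statements on the series, on what has been measured and on what is new or still open speak of the compounds shown alone.

Measured compounds:
compound 1 `CC(=O)NC[C@H]1CN(c2ccc(OC[C@@H](O)CNc3ccccc3)c(F)c2)C(=O)O1` — 1.42
compound 2 `CC(=O)NC[C@H]1CN(c2ccc(OC[C@@H](O)CNc3cc(C(F)(F)F)cc(C(F)(F)F)c3)c(F)c2)C(=O)O1` — 3.1
compound 3 `CC(=O)NC[C@H]1CN(c2ccc(OC[C@@H](O)CNc3cccnc3)c(F)c2)C(=O)O1` — 0.02

In a physicochemical assay for lipophilicity, read by HPLC (a lower number here means a more polar compound, a higher number a more lipophilic compound), compound 1 gives 1.42, the second highest of the three numbers. Compound 2 sits higher at 3.1, compound 3 lower at 0.02; both gaps from compound 1 are beyond the scatter.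

The unmeasured compound 4 `CC(=O)NC[C@H]1CN(c2ccc(OC[C@@H]3CNC(=O)O3)c(F)c2)C(=O)O1` differs from compound 1 in one place: 2-oxo-1,3-oxazolidin-5-yl in place of 2-anilino-1-hydroxyethyl on a saturated chain carbon bound to an oxygen on an aromatic ring. Among the compounds with values here, the only measured step that touches the same side chain is the one to compound 3, a number 1.40 log units lower from compound 1 to compound 3 (beyond the scatter), where the phenyl was merely exchanged for pyridin-3-yl. Within the data shown here, in compound 4 the whole six-membered aromatic ring of carbon only leaves and a five-membered non-aromatic ring with two hetero atoms enters, so a drop in this assay of at least that order is expected, with the uncertainty wider since no measured compound carries the 2-oxo-1,3-oxazolidin-5-yl group. Compound 4 is therefore expected at 0 (range -0.6 to 0.6), an estimated step of a number 1.42 log units lower from compound 1 to compound 4 (beyond the scatter).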

Compound 4, partition coefficient: 0.01
Beside the measured number, compound 4's estimate is 0.01 log units below it; low and high end bracket the measured number.
By their numbers in this assay, from the lowest: compounds 4 and 3 (each within the scatter of the next); then compound 1; then compound 2.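

Working notes: at this position, on a saturated chain carbon bound to an oxygen on an aromatic ring, the whole side chain can be exchanged and not only its aryl group, giving a number 1.41 log units lower from compound 1 to compound 4 (beyond the scatter) in this assay. The 2-oxo-1,3-oxazolidin-5-yl group, which has no hydroxyl-bearing chain and no aromatic ring of its own, and the 1-hydroxy-2-((pyridin-3-yl)amino)ethyl group are not told apart by this assay, with a number 0.01 log units lower from compound 3 to compound 4 (within the scatter). No available evidence accounts for either step.

Which part of the 2-oxo-1,3-oxazolidin-5-yl group sets this number remains open. Also open, going by these compounds, is where this assay would place an open-chain carbamate, a primary amine, or the same ring with a methyl group on its nitrogen at this position.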